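Hydrazone thioether pair: tetrazole versus thiadiazole

The source may report more compounds than this note shows. Statements on the series, on what has been measured and on what is new or still open speak of the compounds shown alone.

Measured so far:
compound 1 `Cc1nnc(SCC(=O)N/N=c2/scc(-c3ccccc3)n2-c2ccccc2)s1`: 61.8%
compound 2 `Cc1ccc(-c2cs/c(=N/NC(=O)CSc3nnnn3C)n2-c2ccccc2)cc1`: 39.7%

In a functional assay on C6 cells (Rattus norvegicus) for cytotoxicity, read by MTT assay, with a stated time of 24 h, tested at 100 ug/mL (a lower number here means a stronger effect, a higher number a weaker effect of the compound at the concentration tested), compound 1 gives 61.8% and compound 2 gives 39.7%. Compound 2 thus holds the lowest of the two numbers, and its gap to compound 1 lies beyond the scatter. Among the compounds with values here, no pair of measured compounds differs in a single place, so what the heteroaryl alone contributes is not yet known.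

Compound 3 `Cc1ccc(-c2cs/c(=N/NC(=O)CSc3nnc(C)s3)n2-c2ccccc2)cc1` has not been measured in this assay. It differs from compound 2 by 5-methyl-1,3,4-thiadiazol-2-yl in place of 1-methyl-1H-tetrazol-5-yl on a sulfur. Within the data shown here, the group that enters is the one carried by compound 1, while the rest of compound 3 matches compound 2. The step from compound 2 to compound 3 is expected to be upward but modest, near the edge of the scatter, because compound 1 gives 61.8% with a different aryl as well; the expected step is a number 10.3 percentage points higher from compound 2 to compound 3 (beyond the scatter). For compound 3 a value of 50% is estimated in this assay, with a range from 35% to 66%.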

Compound 3, a percentage reported as activity, at one concentration (the size of the read-out at that concentration, not a potency): 31.5%
Compound 3: middle estimate off by 18.5 percentage points, on the high side, outside the stated range (below it).
By their numbers in this assay, from the lowest: compounds 3 and 2 (each within the scatter of the next); then compound 1.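

With the aryl held constant, exchanging 1-methyl-1H-tetrazol-5-yl for 5-methyl-1,3,4-thiadiazol-2-yl on the sulfur gives a number 8.2 percentage points lower from compound 2 to compound 3 (within the scatter) in this assay, so this position tolerates either ring without a change that can be read. With the thiadiazole held constant, methyl in place of hydrogen on an aromatic carbon gives a number 30.3 percentage points lower from compound 1 to compound 3 (beyond the scatter), making this the only single-place change shown that exceeds the scatter. Nothing available explains either step.

Whether the methyl step holds with the tetrazole on the sulfur remains open, as the single-place pair for that comparison is absent from the compounds shown. Also open, on these data alone, is how an amine or a carboxylic acid would read on the sulfur, and whether chlorine or a longer chain could take the place of the aromatic methyl.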